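A Fluorine on the Fused Ring: Expecting Little Change

A few compounds are considered here, and "the series" means these few. Any claim that something is new, unique, unknown or untested is made for them only; others in the source may bear on it.

Compound 1 `COc1ccc(-c2cc(C(=O)Nc3ccc(Oc4ccnc5cc(OCCCN6CCCCC6)c(OC)cc45)c(F)c3)c3ccccc3n2)cc1` is one of three amides built on a shared core. In a functional assay on HT-29 cells (Homo sapiens) for cytotoxicity, read by MTT assay, with a stated time of 72 h (on this read-out lower numbers stand for stronger inhibition and higher numbers for weaker inhibition), compound 1 gives 690 nM, the second highest of the three numbers. Compound 2 `COc1cc2c(Oc3ccc(NC(=O)c4cc(-c5cccc(Cl)c5)nc5ccccc45)cc3F)ccnc2cc1OCCCN1CCCCC1` gives 62 nM, and compound 3 `COc1cc2c(Oc3ccc(NC(=O)c4cc(-c5ccc(Cl)c(Cl)c5)nc5ccccc45)cc3F)ccnc2cc1OCCCN1CCCCC1` gives 1210 nM. The step of an 11-fold lower number from compound 1 to compound 2 (1.05 log units; beyond the scatter) is large, whereas a 1.8-fold higher number from compound 1 to compound 3 (0.24 log units; within the scatter) stays within the scatter; both steps replace the 4-methoxyphenyl group. Compound 4 `COc1ccc(-c2cc(C(=O)Nc3ccc(Oc4ccnc5cc(OCCCN6CCCCC6)c(OC)cc45)c(F)c3)c3cc(F)ccc3n2)cc1` differs from compound 1 somewhere else: fluoro in place of hydrogen on an aromatic carbon. For the measured compounds named here, no measured step touches this part of the shared core, so the measured steps give no guidance here. With nothing pointing either way, compound 4 is expected to show no step beyond the scatter, meaning no change at the digits printed from compound 1 to compound 4 (within the scatter). The estimate for compound 4 is 690 nM, with a range from 250 nM to 1900 nM.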

Compound 4, half-maximal inhibitory concentration: 600 nM
Beside the measured number, compound 4's estimate is 1.2-fold (0.06 log units) above it, and the stated range covers the measured number.
By their numbers in this assay, from the lowest: compound 2; then compounds 4, 1 and 3 (each within the scatter of the next).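

Fluoro in place of hydrogen at this position gives a 1.2-fold lower number from compound 1 to compound 4 (0.06 log units; within the scatter) in this assay and adds a first reading for this part of the shared core. With the 4-methoxyphenyl group in place, this aromatic carbon carries a single fluorine atom with no change beyond the scatter. No available evidence bears on this result. Still open, as far as these compounds go, is how an amine or a carboxylic acid at this position would read. Also open, from the compounds shown here alone, is whether fluoro would leave the number as unmoved alongside the 3-chlorophenyl group of compound 2.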